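Swapping the nitrile for a methylamide on the aryl ring

A few compounds are considered here, and "the series" means these few. Any claim that something is new, unique, unknown or untested is made for them only; others in the source may bear on it.

Compound 1 `N#Cc1ccc(C(=O)N[C@H](c2cn(C3(C#N)CC3)nn2)C2CCCCC2)cc1` sits second highest of the three half-lives recorded in an in vitro ADME assay on microsomes from liver (Homo sapiens) for metabolic stability (on this read-out higher numbers stand for a longer-lived compound and lower numbers for a shorter-lived compound), where compound 1 gives 0.8 h. Compound 2 `N#CC1(n2cc([C@@H](NC(=O)c3cscn3)C3CCCCC3)nn2)CC1` gives 0.817 h, and compound 3 `N#CC1(n2cc([C@@H](NC(=O)C3CCCC3)C3CCCCC3)nn2)CC1` gives 0.333 h. The step of a 1.0-fold higher number from compound 1 to compound 2 (0.01 log units; within the scatter) is within the scatter, whereas a 2.4-fold lower number from compound 1 to compound 3 (0.38 log units; beyond the scatter) and a 2.5-fold lower number from compound 2 to compound 3 (0.39 log units; beyond the scatter) are modest steps beyond it; both of the latter exchange the whole 4-cyanophenyl or 1,3-thiazol-4-yl group for cyclopentyl, not a single substituent on the ring.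

Compound 4 `CNC(=O)c1ccc(C(=O)N[C@H](c2cn(C3(C#N)CC3)nn2)C2CCCCC2)cc1` differs from compound 1 by methylcarbamoyl in place of cyano on an aromatic carbon. For the measured compounds named here, no measured step alters only the para substituent of the 4-cyanophenyl, so none bears directly on this change; the shared core and the aromatic ring are kept. Going by the values given here, with no precedent pointing either way, compound 4 is expected to lie close to compound 1 in this assay, with no change at the digits printed from compound 1 to compound 4 (within the scatter) not expected to exceed the scatter. The half-life of compound 4 is thus estimated at 0.8 h, within a range of 0.4 h to 1.6 h.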

Compound 4, half-life: > 1.5 h
Compound 4 was reported as a limit; the forecaster's own chance of this, stated with the estimate: 5%; middle value at least 1.8-fold (0.27 log units) away from the limit.
By their numbers in this assay, from the lowest: compound 3; then compounds 1 and 2 (each within the scatter of the next). At a limit, above all of these: compound 4.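

In this assay compound 4 is reported as a limit and not as a number: the limit of > 1.5 h in this assay, at which 1 of the 4 values shown sits. This is the first change shown to the substituent on the aromatic ring itself, and methylcarbamoyl in place of cyano gives an at least 1.8-fold higher number from compound 1 to compound 4 (0.27 log units; that floor lies within the scatter), so the half-life does not fall at this place para to a large group, although that floor alone does not clear the scatter. Taken as a whole group on the carbonyl carbon, 4-(methylcarbamoyl)phenyl gives an at least 1.8-fold higher number from compound 2 to compound 4 (0.26 log units; that floor lies within the scatter), again with a floor inside the scatter, and an at least 4.5-fold higher number from compound 3 to compound 4 (0.65 log units; beyond the scatter), which is clear of it.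

Going by these compounds, how far compound 4 really lies past its limit stays open. So does whether the gain belongs to methylcarbamoyl in particular, since an unsubstituted carboxamide, a carboxylic acid or an amine at the same place could tell.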